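Working notes: three measured compounds, a fourth awaited

The source may hold more compounds than are shown below. What is called first, only, known or untested is meant among the compounds shown, and "the series" means these compounds.

Measured so far in a functional assay on CHO cells with adenosine receptor A1 (Homo sapiens) as the target, read by cAMP accumulation and immunoassay, with a stated time of 6 min, tested at 10 uM; on this read-out lower numbers stand for a stronger effect and higher numbers for a weaker effect at the one concentration tested:
compound 1 `Nc1scc(CN2CCN(c3cc(Cl)cc(Cl)c3)CC2)c1C(=O)c1ccc(Cl)cc1`: -74%
compound 2 `Nc1scc(CN2CCN(c3cccc(C(F)(F)F)c3)CC2)c1C(=O)c1ccc(Cl)cc1`: -80%
compound 3 `Nc1scc(CN2CCN(c3cccnc3)CC2)c1C(=O)c1ccc(Cl)cc1`: -23%

Compound 2 gives the lowest number of the three. The nearest is compound 1, and the step of a number 6 percentage points lower from compound 1 to compound 2 (within the scatter) lies within the scatter, so no order between compounds 1 and 2 can be claimed. The furthest is compound 3: the step of a number 57 percentage points higher from compound 2 to compound 3 (beyond the scatter) is large, as is the step of a number 51 percentage points higher from compound 1 to compound 3 (beyond the scatter).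

Compound 4 `Nc1scc(CN2CCN(c3ccc(F)c(Cl)c3)CC2)c1C(=O)c1ccc(Cl)cc1` has not been measured. Its difference from compound 2 is 3-chloro-4-fluorophenyl in place of 3-(trifluoromethyl)phenyl on an amine nitrogen in a ring.

Within the data shown here, two measured steps bear on this. The step from compound 1 to compound 2 exchanges one halogen-bearing six-membered aromatic ring of carbon only for another and stays within the scatter. The steps to compound 3 exchange such a ring for pyridin-3-yl and are large, but compound 4 keeps a six-membered aromatic ring of carbon only, so those steps speak less directly. The expected step of a number 10 percentage points higher from compound 2 to compound 4 (within the scatter) is therefore small, likely none beyond the scatter, if anything toward a higher number.

For compound 4 the estimated value in this assay is -70%, with an expected range from -86% to -45%.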

Compound 4, a percentage reported as activity, at one concentration (the size of the read-out at that concentration, not a potency): -78%
Compound 4: middle estimate off by 8 percentage points, on the high side; the range from low to high includes it.
By their numbers in this assay, from the lowest: compounds 2, 4 and 1 (each within the scatter of the next); then compound 3.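

In this assay, the step of a number 2 percentage points higher from compound 2 to compound 4 (within the scatter) and the step of a number 4 percentage points lower from compound 1 to compound 4 (within the scatter) show that 3-chloro-4-fluorophenyl on the amine nitrogen in the ring cannot be told apart from 3-(trifluoromethyl)phenyl or 3,5-dichlorophenyl, so this position now accepts three differently substituted six-membered aromatic rings of carbon only with no step beyond the scatter. Among these compounds, the step of a number 55 percentage points lower from compound 3 to compound 4 (beyond the scatter) is large and leaves pyridin-3-yl as the one group set apart from the other three, with no compound among the four going against that split. No measurement at hand explains this split or the lack of separation among the other three groups.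

The compounds shown leave open whether an unsubstituted phenyl, a phenyl carrying a methoxy group, an amine or a carboxylic acid, or a pyridin-4-yl group would read with the three halogen-bearing rings or with pyridin-3-yl. With a single concentration behind each number, they also leave open whether compounds 1, 2 and 4 would differ in the size of their effect at other concentrations, which a full concentration series would be needed to settle.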